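The source may hold more compounds than are shown below. What is called first, only, known or untested is meant among the compounds shown, and "the series" means these compounds.

Compound 1 `C[C@@H]1CN([C@@H](C)CO)C(=O)c2cccc(NC(=O)NCc3cccc4ccccc34)c2O[C@H]1CN(C)S(=O)(=O)c1ccc2c(c1)OCCO2` gives 100 nM in a physicochemical assay for solubility, read by HPLC, in phosphate buffer, measured as thermodynamic solubility, with a stated time of 24 h, at pH 7.4; a lower number here means a less soluble compound, a higher number a more soluble compound; compound 2 `C[C@@H]1CN([C@@H](C)CO)C(=O)c2cccc(NC(=O)N(C)c3cccc4ccccc34)c2O[C@H]1CN(C)S(=O)(=O)c1ccc2c(c1)OCCO2` gives 11200 nM.

Among the compounds with values here, of these two numbers compound 2 holds the higher one, its only neighbour being compound 1 at a 110-fold higher number from compound 1 to compound 2 (2.05 log units; beyond the scatter). Within the data shown here, that single step, in which a methyl moved onto the urea nitrogen and the methylene between that nitrogen and the ring was lost, is the one piece of measured information bearing on the next change. Compound 3 `C[C@@H]1CN([C@@H](C)CO)C(=O)c2cccc(NC(=O)Nc3nccc4ccccc34)c2O[C@H]1CN(C)S(=O)(=O)c1ccc2c(c1)OCCO2` differs from compound 2 by (isoquinolin-1-yl)amino in place of methyl(naphthalen-1-yl)amino on a carbonyl carbon. The entering group returns a hydrogen-bond donor to the urea nitrogen, as in compound 1, and brings one acceptor that neither earlier compound has. The measured step therefore points partly backwards: a drop from compound 2 is expected, but not the full return. The expected step is a 28-fold lower number from compound 2 to compound 3 (1.45 log units; beyond the scatter), giving compound 3 an estimated 400 nM, within 60 nM to 3000 nM.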

Compound 3, solubility: 700 nM
For compound 3 the middle estimate is 1.8-fold (0.24 log units) below the measured one, within the range that was stated.
By their numbers in this assay, from the lowest: compound 1; then compound 3; then compound 2.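

In this assay, (isoquinolin-1-yl)amino on the carbonyl carbon gives a 16-fold lower number from compound 2 to compound 3 (1.20 log units; beyond the scatter), so this position still responds strongly when the group on the urea changes. Set against the other earlier compound, isoquinolin-1-yl in place of (naphthalen-1-yl)methyl on the amide-type nitrogen gives a 7.0-fold higher number from compound 1 to compound 3 (0.85 log units; beyond the scatter), which shows that two compounds that both keep a hydrogen on this nitrogen can still differ beyond the scatter, with both lying below compound 2. Nothing available here gives a measured reason for either step.

From the compounds shown here alone, the step away from compound 2 removes the methyl and replaces the ring at once, so the share of each remains unknown. A (naphthalen-1-yl)amino group or a methyl(isoquinolin-1-yl)amino group at this position would change only one of the two and separate those shares.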